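This account rests on a few compounds, and the source may have more. Where it says the series, first, only, none or still open, it means among the compounds named here.

Compounds measured so far:
compound 1 `COc1cccc(CN2C(=O)CN(C(=O)c3cc4cc(OC)ccc4[nH]3)C[C@@H]2COCc2ccccc2)c1`: 11700 nM
compound 2 `COc1cccc(CN2C(=O)CN(C(=O)c3cc4cc(OC)ccc4[nH]3)C[C@@H]2CC2CCCCC2)c1`: 21400 nM

Both values were read in a physicochemical assay for solubility, read by spectrophotometry, in phosphate buffer, with a stated time of 2 h, at pH 7.4; a lower number here means a less soluble compound, a higher number a more soluble compound. Compound 2 has the higher of the two numbers, but the step of a 1.8-fold higher number from compound 1 to compound 2 (0.26 log units; within the scatter) lies within the scatter, so the two compounds cannot be told apart on solubility. Compound 3 `COc1cccc(CN2C(=O)CN(C(=O)c3cc4cc(OC)ccc4[nH]3)C[C@@H]2Cc2ccccn2)c1` has not yet been measured. It differs from compound 2 by pyridin-2-yl in place of cyclohexyl on a saturated chain carbon bound to a saturated ring carbon. Going by the values given here, the only step recorded so far concerns a different exchange at the same place, a 1.8-fold higher number from compound 1 to compound 2 (0.26 log units; within the scatter), and it was within the scatter; no measured pair shows the present change. On that basis the step of a 1.2-fold higher number from compound 2 to compound 3 (0.07 log units; within the scatter) is expected to stay near compound 2, with no clear direction. Compound 3 is therefore estimated at 25000 nM, within a range from 9000 nM to 70000 nM.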

Compound 3, solubility: 57900 nM
Compound 3: middle estimate off by 2.3-fold (0.36 log units), on the low side; the measured number falls inside the stated range.
By their numbers in this assay, from the lowest: compounds 1 and 2 (each within the scatter of the next); then compound 3.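

In this assay, this place on the saturated chain carbon bound to a saturated ring carbon now shows a step beyond the scatter, a 2.7-fold higher number from compound 2 to compound 3 (0.43 log units; beyond the scatter), which the exchange of benzyloxy for cyclohexyl did not show. The exchange of benzyloxy for pyridin-2-yl at the same place, a 4.9-fold higher number from compound 1 to compound 3 (0.69 log units; beyond the scatter), is also beyond the scatter, so compound 3 stands apart from both earlier compounds. Cyclohexyl and pyridin-2-yl each hold 6 heavy atoms, so this step comes with no change in that count, while the entering ring is aromatic, contains nitrogen and counts 1 hydrogen-bond acceptor.

Nothing available explains the step. The compounds shown leave open whether phenyl at this place would stand with compound 2 or compound 3, and whether a ring-bearing amine would follow either one.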